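From compound 3 to compound 4: an aryl exchange

A few compounds are considered here, and "the series" means these few. Any claim that something is new, unique, unknown or untested is made for them only; others in the source may bear on it.

In a functional assay on microsomes for inhibition, with a stated time of 1 h (on this read-out lower numbers stand for stronger inhibition and higher numbers for weaker inhibition), compound 1 (`COc1ccc(-c2nc(SC)n(C)c(=O)c2C#N)cc1`) gives 53 ug/mL while compound 2 (`COc1ccc(-c2nc(NN)n(C)c(=O)c2C#N)cc1`) gives 39 ug/mL and compound 3 (`CCOC(=O)c1cnn(-c2nc(-c3ccc(OC)cc3)c(C#N)c(=O)n2C)c1N`) gives 68 ug/mL with all three numbers lying within the scatter of one another. Compound 3 therefore stands level with compound 1 and compound 2 on these numbers.

Compound 4 (`CCOC(=O)c1cnn(-c2nc(-c3ccccc3F)c(C#N)c(=O)n2C)c1N`) has not yet been measured. It carries 2-fluorophenyl in place of 4-methoxyphenyl on an aromatic carbon ortho to a cyano group. Going by the values given here, all three measured compounds carry 4-methoxyphenyl, so no measured step covers this exchange. Among the compounds with values here, the one step available is a 1.4-fold lower number from compound 1 to compound 2 (0.13 log units; within the scatter) and it concerns a different group, so it offers only indirect guidance. With that small step as the sole reference, no change beyond the scatter is expected in this assay and the expected step is a 1.1-fold lower number from compound 3 to compound 4 (0.05 log units; within the scatter) with the direction left open. For compound 4 the estimate is 60 ug/mL (expected range 25 ug/mL to 140 ug/mL).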

Compound 4, half-maximal inhibitory concentration: 94 ug/mL
Estimate against measurement, compound 4: 1.6-fold (0.19 log units) below, within the range that was stated.
By their numbers in this assay, from the lowest: compounds 2, 1, 3 and 4 (each within the scatter of the next, the first and the last beyond it).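

Going by these compounds alone, replacing 4-methoxyphenyl with 2-fluorophenyl on the aromatic carbon ortho to a cyano group gives the first reading at this position: in this assay there is a 1.4-fold higher number from compound 3 to compound 4 (0.14 log units; within the scatter). In this pair, the exchange removes the methoxy group and its counted hydrogen-bond acceptor and introduces fluorine, with a step that stays within the scatter. No supporting data bear on this result.

Because the exchange alters both the substituent and its place on the phenyl ring, the compounds shown cannot separate the loss of the methoxy group from the arrival of the fluorine; unsubstituted phenyl and 4-fluorophenyl would divide those two changes. On these data alone, it also remains open whether a more different group at this position, such as a pyridyl ring or a phenyl ring bearing a carboxylic acid, would give a step beyond the scatter.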